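The compounds below may be only part of what the source reports. "The series", "measured", "known", "first", "only" and "open" are said of these compounds alone.

Measured compounds so far:

Compound 1, `CN1CCN(C(=O)c2c(NC(=O)NS(=O)(=O)c3ccccc3)sc3c2CCCCC3)CC1`. In a functional assay on OVCAR-3 cells (Homo sapiens) for inhibition, with a stated time of 48 h (on this read-out higher numbers stand for weaker inhibition of growth and lower numbers for stronger inhibition of growth), compound 1 gives > 100000 nM, which is a limit of the assay.
Compound 2, `NNC(=O)c1c(NC(=O)NS(=O)(=O)c2ccccc2)sc2c1CCCCC2`. In this assay compound 2 gives > 100000 nM, again a limit.
Compound 3, `CCCNC(=O)c1c(NC(=O)NS(=O)(=O)c2ccccc2)sc2c1CCCCC2`. In this assay compound 3 gives > 100000 nM, also a limit.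

All three compounds share one core and differ only in the group on the carbonyl carbon. Compound 3 stands at the limit, as do the other two, so no ordering among them can be read. The steps a step that the two limits leave unreadable from compound 1 to compound 2, a step that the two limits leave unreadable from compound 1 to compound 3 and a step that the two limits leave unreadable from compound 2 to compound 3 are all unreadable because of the limit of > 100000 nM in this assay, at which 3 of the 3 values shown sit.

The next compound, compound 4, is `O=C(Nc1sc2c(c1C(=O)NNc1ccc(Br)cc1)CCCCC2)NS(=O)(=O)c1ccccc1`. It differs from compound 3 as follows: (4-bromophenyl)amino in place of propyl on an amide-type nitrogen. As far as these compounds go, the measured steps bear on this change only in that every variation of the carbonyl substituent so far has left compound 1, compound 2 and compound 3 at the limit, so no step size in this assay can be derived from them; the (4-bromophenyl)amino group is a larger change than any of those, and its effect is untested.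

Compound 4 is therefore expected to sit near the limit again, with a step of about a number no higher from compound 3 to compound 4 (the limit leaves the size open) estimated from compound 3. The estimate for compound 4 in this assay is 100000 nM, in the range 15000 nM to 400000 nM.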

Compound 4, concentration for 50% growth inhibition: 14800 nM
Beside the measured number, compound 4's estimate is 6.8-fold (0.83 log units) above it; the measured number lies below the stated range.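

In this assay, the group on the carbonyl carbon proves able to move the read-out off the limit, with an at least 6.7-fold lower number from compound 3 to compound 4 (0.82 log units; beyond the scatter) for (4-bromophenyl)amino in place of propyl on the amide-type nitrogen, and an at least 6.7-fold lower number from compound 1 to compound 4 (0.82 log units; beyond the scatter) for ((4-bromophenyl)amino)amino in place of 4-methylpiperazin-1-yl on the carbonyl carbon. The sharpest comparison is an at least 6.7-fold lower number from compound 2 to compound 4 (0.82 log units; beyond the scatter), for 4-bromophenyl in place of hydrogen on the amine nitrogen: compound 2 already carries that amine nitrogen and stays at a limit, so the nitrogen alone does not give the step, and the 4-bromophenyl group is the one difference between the two compounds. All three steps are bounds rather than sizes, and the steps among compound 1, compound 2 and compound 3 cannot be read, because of this limit: the limit of > 100000 nM in this assay, at which 3 of the 4 values shown sit.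

The compounds shown leave open whether the bromine is needed, which a plain phenyl or a 4-chlorophenyl on the same nitrogen would test. Also open, as far as these compounds go, is whether the amine nitrogen is needed once the ring is present, which a 4-bromophenyl set directly on the amide-type nitrogen would test.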